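This account rests on a few compounds, and the source may have more. Where it says the series, first, only, none or still open, it means among the compounds named here.

Compound 1 `O=[N+]([O-])c1cccc(-c2nn(-c3ccccc3)cc2C(Nc2nc3ccccc3s2)c2c(O)ccc3ccccc23)c1`: 32000 nM
Compound 2 `Cc1cccc(-c2nn(-c3ccccc3)cc2C(Nc2nc3ccccc3s2)c2c(O)ccc3ccccc23)c1`: 18500 nM
Compound 3 `COc1ccc(-c2nn(-c3ccccc3)cc2C(Nc2nc3ccccc3s2)c2c(O)ccc3ccccc23)cc1`: 26200 nM

All three were tested in a functional assay on A549 cells (Homo sapiens) for antiproliferative activity, read by MTT assay, with a stated time of 48 h; a lower number here means a stronger inhibitor, a higher number a weaker inhibitor. Compound 3 stands level with the other two, since a 1.2-fold lower number from compound 1 to compound 3 (0.09 log units; within the scatter) and a 1.4-fold higher number from compound 2 to compound 3 (0.15 log units; within the scatter). Compound 4 `Oc1ccc2ccccc2c1C(Nc1nc2ccccc2s1)c1cn(-c2ccccc2)nc1-c1cccc(Cl)c1` carries 3-chlorophenyl in place of 4-methoxyphenyl on an aromatic carbon of the five-membered aromatic ring with 2 nitrogen (3-chlorophenyl in place of 4-methoxyphenyl on an aromatic carbon). The measured steps changed the group at this same carbon, and a 1.7-fold lower number from compound 1 to compound 2 (0.24 log units; within the scatter) also stayed small, so none of the three left the scatter. No step beyond the scatter is therefore expected in this assay. The expected move is a 1.1-fold lower number from compound 3 to compound 4 (0.06 log units; within the scatter). For compound 4 the estimate is 23000 nM, with an expected range of 12000 nM to 42000 nM.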

Compound 4, half-maximal inhibitory concentration: 20400 nM
Beside the measured number, compound 4's estimate is 1.1-fold (0.05 log units) above it, and the stated range covers the measured number.
By their numbers in this assay, from the lowest: compounds 2, 4, 3 and 1 (each within the scatter of the next).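

In this assay, 3-chlorophenyl at this carbon of the five-membered ring leaves every comparison within the scatter: a 1.3-fold lower number from compound 3 to compound 4 (0.11 log units; within the scatter), a 1.1-fold higher number from compound 2 to compound 4 (0.04 log units; within the scatter) and a 1.6-fold lower number from compound 1 to compound 4 (0.20 log units; within the scatter). Chloro is a fourth group on this phenyl ring, and the four compounds remain level with one another. No measurement shown accounts for this flat result.

On these data alone, whether an amine or a carboxylic acid on this phenyl ring would also leave the number unmoved stays open. So does whether a longer chain in its place could produce a step beyond the scatter.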